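Swapping fluoro for nitro on a urea series

The source may report more compounds than this note shows. Statements on the series, on what has been measured and on what is new or still open speak of the compounds shown alone.

Measured compounds in a functional assay on Daoy cells (Homo sapiens) for cytotoxicity, read by MTT assay, with a stated time of 72 h; a lower number here means a stronger inhibitor, a higher number a weaker inhibitor:
- compound 1 `COc1cc(NC(=O)Nc2cccc(F)c2)cc(OC)c1OC` gives 111000 nM
- compound 2 `COc1ccc([S+]([O-])N(C)c2cc(OC)c(OC)c(OC)c2)cc1` gives >= 125000 nM
- compound 3 `COc1ccc(NC(=O)Nc2cc(OC)c(OC)c(OC)c2)cc1` gives 14900 nM

In this assay compound 1 has the highest of the two numbers reported. The value for compound 2 is a limit of the assay and not a number. Compound 3, which shares the urea linker and the core of compound 1, sits far below: a 7.4-fold lower number from compound 1 to compound 3 (0.87 log units; beyond the scatter). Among the measured compounds shown here, that is the only measured step, and it shows that changing the second aromatic ring can shift the number well beyond the scatter.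

Compound 4 `COc1cc(NC(=O)Nc2cccc([N+](=O)[O-])c2)cc(OC)c1OC` differs from compound 1 in one place: nitro in place of fluoro on an aromatic carbon. For the measured compounds named here, no measured pair shows this exchange, so the step from compound 1 to compound 3 gives only a sense of how much this ring can matter, not the direction here. A change of modest size, if any, is therefore expected, and compound 4 is estimated at 80000 nM, within 25000 nM to 200000 nM, which would mean a 1.4-fold lower number from compound 1 to compound 4 (0.14 log units; within the scatter).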

Compound 4, half-maximal inhibitory concentration: 82500 nM
For compound 4 the middle estimate is 1.0-fold (0.01 log units) below the measured one; measured number inside the range.
By their numbers in this assay, from the lowest: compound 3; then compounds 4 and 1 (each within the scatter of the next). At a limit, above all of these: compound 2.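

On this aromatic carbon, meta to a large group, nitro in place of fluoro brings three heavy atoms in place of one, yet in this assay the result is a 1.3-fold lower number from compound 1 to compound 4 (0.13 log units; within the scatter), so this exchange cannot be told apart from repeat-to-repeat variation. The change with 4-methoxyphenyl in place of 3-fluorophenyl, a 7.4-fold lower number from compound 1 to compound 3 (0.87 log units; beyond the scatter), therefore remains the only step shown that lies beyond the scatter. Nothing measured here gives a reason for the outcome of the nitro exchange.

Still open, going by these compounds, is whether a different group on this carbon, such as an amine or a carboxylic acid, would move the number beyond the scatter. On these data alone, it is also open whether nitro and fluoro would give equally close numbers on a urea that carries the 4-methoxyphenyl ring of compound 3.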